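The source may hold more compounds than are shown below. What is called first, only, known or untested is meant among the compounds shown, and "the series" means these compounds.

Measured so far in a functional assay on K562 cells (Homo sapiens) for cytotoxicity, read by trypan blue exclusion, with a stated time of 96 h; on this read-out higher numbers stand for weaker inhibition and lower numbers for stronger inhibition:
- compound 1 `COc1ccc(N)cc1CS(=O)(=O)/C=C/c1c(OC)cccc1OC`: 25000 nM
- compound 2 `COc1ccc(CS(=O)(=O)/C=C/c2cc(OC)c(OC)c(OC)c2)cc1N`: 250 nM
- compound 3 `COC(=O)CCNc1cc(CS(=O)(=O)/C=C/c2c(OC)cc(OC)cc2OC)ccc1OC`: 1000 nM

Compound 3 holds the second highest of the three numbers. Its gaps to the other two both lie beyond the scatter, with a lower number for compound 2 and a higher number for compound 1.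

The next compound, compound 4 `COC(=O)C(Nc1cc(CS(=O)(=O)/C=C/c2c(OC)cc(OC)cc2OC)ccc1OC)c1ccccc1`, differs from compound 3 in one place: methoxycarbonyl)(benzyl in place of 2-(methoxycarbonyl)ethyl on a nitrogen on an aromatic ring. Within the data shown here, the measured compounds contain no pair differing in one place, so nothing here sizes this change directly. The wide spread among the three values comes from compounds that differ in several places, and it cannot be assigned to any single group. The expectation is therefore anchored on compound 3 at 1000 nM, with no step beyond the scatter in either direction. The estimated 1.3-fold lower number from compound 3 to compound 4 (0.10 log units; within the scatter) is accordingly small. For compound 4 the expected value is 800 nM, with an estimated range from 200 nM to 3500 nM.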

Compound 4, half-maximal inhibitory concentration: 30 nM
Beside the measured number, compound 4's estimate is 27-fold (1.43 log units) above it; measured number below the stated range.
By their numbers in this assay, from the lowest: compound 4; then compound 2; then compound 3; then compound 1.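

In this assay, among these compounds, this is the first step that sizes a change at one place: on the nitrogen on an aromatic ring, methoxycarbonyl)(benzyl in place of 2-(methoxycarbonyl)ethyl gives a 33-fold lower number from compound 3 to compound 4 (1.52 log units; beyond the scatter), a large step beyond the scatter. Among the compounds shown here, the number therefore responds strongly to the group on this nitrogen, which the earlier compounds, differing in several places at once, could not show. Both groups carry the methoxycarbonyl part, and the entering group adds a six-membered aromatic ring of carbon only, but no measurement here explains the step.

For the compounds shown here, the single step changes the chain and adds the ring together, so the share of each stays open. From the compounds shown here alone, how a carboxylic acid or an amide in place of the methoxycarbonyl part, or a plain benzyl group on this nitrogen, would read also remains open.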